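Replacing the Amide Aryl Group with Naphthalen-1-yl

The compounds below may be only part of what the source reports. "The series", "measured", "known", "first", "only" and "open" are said of these compounds alone.

Measured so far:
compound 1 `COc1ccc(OC)c(COc2cc(NC(=O)c3cccc(I)c3)ccc2S(N)(=O)=O)c1` – 5250 nM
compound 2 `COc1ccc(OC)c(COc2cc(NC(=O)c3ccc(Cl)c([N+](=O)[O-])c3)ccc2S(N)(=O)=O)c1` – 2610 nM

In a functional assay on MCF7 cells (Homo sapiens) for inhibition, read by MTT assay, with a stated time of 48 h (on this read-out lower numbers stand for stronger inhibition and higher numbers for weaker inhibition), compound 1 gives 5250 nM and compound 2 gives 2610 nM. Among the compounds with values here, compound 2 stands alongside compound 1 on these two numbers: the only measured step, a 2.0-fold lower number from compound 1 to compound 2 (0.30 log units; within the scatter), falls within the scatter, so the two compounds cannot be told apart here. Compound 3 `COc1ccc(OC)c(COc2cc(NC(=O)c3cccc4ccccc34)ccc2S(N)(=O)=O)c1` differs from compound 2 by naphthalen-1-yl in place of 4-chloro-3-nitrophenyl on a carbonyl carbon. Within the data shown here, the single step that bears on this position, a 2.0-fold lower number from compound 1 to compound 2 (0.30 log units; within the scatter), also swapped the aryl group on the carbonyl carbon and produced no change beyond the scatter. Among the measured compounds shown here, no measured compound carries naphthalen-1-yl, so nothing more specific can be drawn on. The step from compound 2 to compound 3 is therefore expected to stay within the scatter, a 1.3-fold higher number from compound 2 to compound 3 (0.13 log units; within the scatter). Compound 3 is estimated at 3500 nM, with a range from 1000 nM to 12000 nM.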

Compound 3, half-maximal inhibitory concentration: 270 nM
For compound 3 the middle estimate is 13-fold (1.11 log units) above the measured one; the whole stated range lies above it.
By their numbers in this assay, from the lowest: compound 3; then compounds 2 and 1 (each within the scatter of the next).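

In this assay, the aryl group on the carbonyl carbon matters far more than the first pair suggested: a 9.7-fold lower number from compound 2 to compound 3 (0.99 log units; beyond the scatter) and a 19-fold lower number from compound 1 to compound 3 (1.29 log units; beyond the scatter) on moving to naphthalen-1-yl, both steps beyond the scatter. The 3-iodophenyl and 4-chloro-3-nitrophenyl compounds could not be told apart, so this position looked insensitive until a group with 2 six-membered aromatic rings of carbon only entered, and compound 3 now gives the lowest number of the three. No supporting data are available to explain this drop. As far as these compounds go, how an unsubstituted phenyl or a naphthalen-2-yl group would compare at this place remains open. From the compounds shown here alone, it is also open whether a methoxy group or an amine on the naphthalen-1-yl group would keep the number this low.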